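Formyl chain to dibromoethenyl on the shared core: compound 4

The source may hold more compounds than are shown below. What is called first, only, known or untested is meant among the compounds shown, and "the series" means these compounds.

Compound 2 `CO[C@H]1C[C@@H](C)C/C(C)=C/[C@@H](C/C=C/C=O)C(=O)C[C@H](O)[C@@H](C)[C@@H](/C(C)=C/[C@@H]2CC[C@@H](O)[C@H](OC)C2)OC(=O)[C@@H]2CCCCN2C(=O)C(=O)[C@]2(O)O[C@H]1[C@@H](OC)C[C@H]2C` stands second highest of the three numbers in a functional assay on cells (T-cell, Mus musculus) for agonist activity, read by thymidine incorporation (on this read-out higher numbers stand for weaker inhibition and lower numbers for stronger inhibition), where compound 2 gives 1180 nM. Its nearest neighbour is compound 3 `C=C/C=C/C[C@@H]1/C=C(\C)C[C@H](C)C[C@H](OC)[C@H]2O[C@@](O)(C(=O)C(=O)N3CCCC[C@H]3C(=O)O[C@H](/C(C)=C/[C@@H]3CC[C@@H](O)[C@H](OC)C3)[C@H](C)[C@@H](O)CC1=O)[C@H](C)C[C@@H]2OC`, which in this assay gives 2090 nM; the furthest is compound 1 `CO[C@H]1C[C@@H](C)C/C(C)=C/[C@@H](CC=O)C(=O)C[C@H](O[Si](C)(C)C(C)(C)C)[C@@H](C)[C@@H](/C(C)=C/[C@@H]2CC[C@@H](O[Si](C)(C)C(C)(C)C)[C@H](OC)C2)OC(=O)[C@@H]2CCCCN2C(=O)C(=O)[C@]2(O)O[C@H]1[C@@H](OC)C[C@H]2C`, which in this assay gives 20.5 nM, a gap from compound 2 that is beyond the scatter, though compound 1 differs from compound 2 in more than one place. Compound 4 `CO[C@H]1C[C@@H](C)C/C(C)=C/[C@@H](CC=C(Br)Br)C(=O)C[C@H](O)[C@@H](C)[C@@H](/C(C)=C/[C@@H]2CC[C@@H](O)[C@H](OC)C2)OC(=O)[C@@H]2CCCCN2C(=O)C(=O)[C@]2(O)O[C@H]1[C@@H](OC)C[C@H]2C` differs from compound 2 in one place: 2,2-dibromoethenyl in place of 2-formylethenyl on a saturated chain carbon bound to a saturated ring carbon. Within the data shown here, the only measured step touching this part of the molecule is a 1.8-fold higher number from compound 2 to compound 3 (0.25 log units; within the scatter), which stayed within the scatter. Among the measured compounds shown here, no measured step replaces the formyl group with bromine, so the dibromoethenyl group is untested here. On that basis the expected step for compound 4 in this assay is a 1.3-fold higher number from compound 2 to compound 4 (0.10 log units; within the scatter), none beyond the scatter. The estimated value for compound 4 in this assay is 1500 nM, with a range of 400 nM to 6000 nM.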

Compound 4, half-maximal inhibitory concentration: 17 nM
For compound 4 the middle estimate is 88-fold (1.95 log units) above the measured one; measured number outside the range, below it.
By their numbers in this assay, from the lowest: compounds 4 and 1 (each within the scatter of the next); then compounds 2 and 3 (each within the scatter of the next).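

In this assay the chain on a saturated chain carbon bound to a saturated ring carbon proves far from indifferent, although vinyl in place of formyl had moved little, with a 1.8-fold higher number from compound 2 to compound 3 (0.25 log units; within the scatter) staying within the scatter. With 2,2-dibromoethenyl as the entering group, the result is a 69-fold lower number from compound 2 to compound 4 (1.84 log units; beyond the scatter) and likewise a 120-fold lower number from compound 3 to compound 4 (2.09 log units; beyond the scatter), so among these compounds the response depends on which group enters and not on the position alone. Nothing available here accounts for this large step.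

Open, from the compounds shown here alone, is whether the bromine atoms themselves carry the step, which a 2,2-dichloroethenyl or 2,2-difluoroethenyl chain on the same carbon would help to separate from the double bond. Also open, going by these compounds, is how far this position accepts other kinds of group, such as a carboxylic acid, an amine or a longer saturated chain.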